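Compound 4: a ring group replaces the (nitrooxy)methyl group

The source may report more compounds than this note shows. Statements on the series, on what has been measured and on what is new or still open speak of the compounds shown alone.

In a functional assay (aorta) with Rattus norvegicus as the target, in the presence of a further agent that is not named here (on this read-out lower numbers stand for an effect already at smaller amounts and higher numbers for an effect only at larger amounts of compound), compound 1 `COC(=O)C1=C(C)N=C(C)/C(=C(/O)OC)C1c1cccc(OCCO[N+](=O)[O-])c1` gives 750 nM, compound 2 `COC(=O)C1=C(C)N=C(C)/C(=C(/O)OC)C1c1ccccc1OCc1nonc1C(N)=O` gives 970 nM and compound 3 `COC(=O)C1=C(C)N=C(C)/C(=C(/O)OC)C1c1ccccc1OCc1no[n+]([O-])c1C(N)=O` gives 550 nM, so compound 1 lies within the usual scatter of both others. Compound 4 `COC(=O)C1=C(C)N=C(C)/C(=C(/O)OC)C1c1cccc(OCc2c(C#N)no[n+]2[O-])c1` differs from compound 1 by this change: a group of 8 heavy atoms (3 carbon, 3 nitrogen, 2 oxygen; one five-membered aromatic ring with 3 hetero atoms) in place of a group of 5 heavy atoms (1 carbon, 1 nitrogen, 3 oxygen; no ring), on a saturated chain carbon bound to an oxygen on an aromatic ring. Among the compounds with values here, compound 2 and compound 3 also carry a five-membered aromatic ring with 3 hetero atoms, and the one measured step between them, a 1.8-fold lower number from compound 2 to compound 3 (0.25 log units; within the scatter), stays within the scatter. Within the data shown here, no measured compound has the triple bond of the entering group, so uncertainty remains. The step expected in this assay is therefore small, an estimated 1.5-fold lower number from compound 1 to compound 4 (0.18 log units; within the scatter), and none beyond the scatter. Compound 4 is expected at 500 nM, within an estimated range of 170 nM to 1400 nM.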

Compound 4, half-maximal effective concentration: 11 nM
Compound 4: middle estimate off by 45-fold (1.66 log units), on the high side; the measured number lies below the stated range.
By their numbers in this assay, from the lowest: compound 4; then compounds 3, 1 and 2 (each within the scatter of the next).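

In this assay, swapping the (nitrooxy)methyl group for the ring group with its nitrile brings a 68-fold lower number from compound 1 to compound 4 (1.83 log units; beyond the scatter) and so shows that a change on this saturated chain carbon bound to an oxygen on an aromatic ring can move the number far beyond the scatter. The earlier step, a 1.8-fold lower number from compound 2 to compound 3 (0.25 log units; within the scatter), gave no sign of a change this large. No measurement shown here accounts for the drop. Going by these compounds, whether the ring or its nitrile carries the step stays open, and so does what a methyl group or a carboxylic acid in place of the nitrile would do.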